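Changing the ring on the side chain of compound 3

The compounds below may be only part of what the source reports. "The series", "measured", "known", "first", "only" and "open" are said of these compounds alone.

Measured so far:
- compound 1 `Nc1nc(-c2ccco2)nc2sc(CN3CC=CCC3)cc12`: 150 nM
- compound 2 `Nc1nc(-c2ccc(Cl)o2)nc2sc(CN3CCCC3)cc12`: 710 nM
- compound 3 `Nc1nc(-c2ccc(Cl)o2)nc2sc(CN3CCCCCC3)cc12`: 1420 nM

In an assay on CHO-K1 cells for antagonist activity at adenosine receptor A1 (Homo sapiens), read by a beta-galactosidase reporter, with stated times of 15 min and 6 h (a higher number here means a weaker inhibitor, a lower number a stronger inhibitor), compound 3 gives the highest of the three numbers. Going by the values given here, its nearest neighbour is compound 2, and the step of a 2.0-fold higher number from compound 2 to compound 3 (0.30 log units; within the scatter) is the only one-place change measured here; compound 1 lies furthest away, with a clearly lower number.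

The next compound, compound 4 `Nc1nc(-c2ccc(Cl)o2)nc2sc(CN3CC=CCC3)cc12`, keeps the shared core of compound 3 and alters only the ring on the side chain: a group of 6 heavy atoms (5 carbon, 1 nitrogen; one six-membered non-aromatic ring with 1 hetero atom) in place of a group of 7 heavy atoms (6 carbon, 1 nitrogen; one seven-membered non-aromatic ring with 1 hetero atom), on a saturated chain carbon bound to an aromatic carbon. Among the compounds with values here, the one measured step that bears on this place, the step from compound 2 to compound 3, swapped a five-membered ring for a seven-membered one and stayed within the scatter. The ring entering in compound 4 has an intermediate size, so on that evidence alone little change would be expected. Compound 1, however, carries this same six-membered ring and differs from compound 4 at one other place; in this assay compound 1 gives 150 nM, which hints at a lower number than compound 3.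

Weighing both, the expected move for compound 4 is a 2.4-fold lower number from compound 3 to compound 4 (0.37 log units; beyond the scatter), with an estimate of 600 nM and a range from 200 nM to 1800 nM.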

Compound 4, inhibition constant: 190 nM
For compound 4 the middle estimate is 3.2-fold (0.50 log units) above the measured one, and the stated range ends above it.
By their numbers in this assay, from the lowest: compounds 1 and 4 (each within the scatter of the next); then compounds 2 and 3 (each within the scatter of the next).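

Swapping one ring for another on the side chain can clearly move the number in this assay, even though the first swap seen here, a 2.0-fold higher number from compound 2 to compound 3 (0.30 log units; within the scatter), stayed within the scatter: the ring in compound 4 brings a 7.5-fold lower number from compound 3 to compound 4 (0.87 log units; beyond the scatter) and a 3.7-fold lower number from compound 2 to compound 4 (0.57 log units; beyond the scatter), both beyond the scatter. The other position behaves differently, since chloro in place of hydrogen on an aromatic carbon gives a 1.3-fold higher number from compound 1 to compound 4 (0.10 log units; within the scatter), which is within the scatter, so with this side-chain ring the chloro group makes no readable difference. Nothing measured here explains why this ring stands apart from the five- and seven-membered rings.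

The ring in compound 4 differs from those in compound 2 and compound 3 both in its size and in its double bond outside aromatic rings, so these compounds cannot show which of the two features goes with the lower number. Piperidin-1-yl, a six-membered ring with no such double bond, would separate the two, while morpholin-4-yl would show how a ring oxygen fares at the same place.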